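The compounds below may be only part of what the source reports. "The series", "measured", "known", "first", "only" and "open" are said of these compounds alone.

Measured compounds:
- compound 1, `CC1(C)CC(=O)C=C(Nc2ccc(Cl)cc2Cl)C1`: > 20 ug/mL
- compound 2, `CCCCCCCCCCCSC(=S)C1=C(Nc2ccc(Cl)cc2Cl)CC(C)(C)CC1=O`: > 20 ug/mL

Both measured compounds share the same core, and neither gives a number in a functional assay on PBMC cells (Homo sapiens) for inhibition, read by ELISA, with a stated time of 18 h; on this read-out lower numbers stand for stronger inhibition and higher numbers for weaker inhibition. For compound 1 the result is a limit of the assay, > 20 ug/mL. For compound 2 the result is likewise only a limit, > 20 ug/mL. Compound 2 therefore stands at the limit of > 20 ug/mL in this assay, at which 2 of the 2 values shown sit, with no ordering between it and compound 1 possible on what is shown.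

Compound 3, `CC1(C)CC(=O)C(C(=S)SCCO)=C(Nc2ccc(Cl)cc2Cl)C1`, has not yet been tested in this assay. It differs from compound 2 in one place: hydroxy in place of nonyl on a saturated chain carbon, two bonds along the chain from a sulfur. Nothing measured links this change to a change in inhibition, since neither neighbour of the step has a number.

With both measured compounds sitting at the limit, the step from compound 2 to compound 3 is expected to be small or none beyond the scatter, a step that the limit leaves unreadable from compound 2 to compound 3, and a further limit is the most likely outcome. Compound 3 is estimated at 25 ug/mL, with a range from 6 ug/mL to 80 ug/mL.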

Compound 3, half-maximal inhibitory concentration: > 20 ug/mL
Compound 3: no number, only a limit; the forecaster's own chance of this, stated with the estimate: 65%; the middle value is on the limit's open side.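

In this assay the steps from compound 1 and from compound 2 to compound 3 cannot be read, as all three results are limits and not numbers: the limit of > 20 ug/mL in this assay, at which 3 of the 3 values shown sit. The compounds shown leave open whether any member of this series reaches a measurable inhibition, and whether hydroxy in place of nonyl changes it.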